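Compound 1 to compound 3: opening the piperidine group

This account rests on a few compounds, and the source may have more. Where it says the series, first, only, none or still open, it means among the compounds named here.

Within the data shown here, in a functional assay on PC-3 cells (Homo sapiens) for antiproliferative activity, with a stated time of 72 h (a higher number here means a weaker inhibitor, a lower number a stronger inhibitor), compound 1 `COc1cc(OC)c(C(=O)/C=C/c2ccccc2Cl)c(O)c1CN1CCCCC1` gives 1700 nM as the lower of the two numbers so far. Compound 2 `COc1cc(O)c2c(=O)cc(-c3ccccc3Cl)oc2c1CN1CCCCC1` gives 63400 nM in this assay and the gap between the two values lies beyond the usual scatter. These two compounds differ in more than one place, so their gap does not isolate any single change.

Among the measured compounds shown here, compound 3 `CCN(C)Cc1c(OC)cc(OC)c(C(=O)/C=C/c2ccccc2Cl)c1O` is next and has no measurement yet. The change ethyl(methyl)amino in place of piperidin-1-yl on a saturated chain carbon bound to an aromatic carbon amounts to ethyl(methyl)amino in place of piperidin-1-yl on a saturated chain carbon bound to an aromatic carbon, with the rest of compound 1 kept. For the measured compounds named here, the series holds no measured pair with a change at this place, so the direction of any shift cannot be read from the data. The expectation therefore starts from compound 1 at 1700 nM and assumes no shift beyond the scatter in this assay, with only a slight allowance for a higher number. The estimated step is a 1.2-fold higher number from compound 1 to compound 3 (0.07 log units; within the scatter) and it is expected to stay within the scatter. For compound 3 the estimated value is 2000 nM with an expected range of 800 nM to 6000 nM around it.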

Compound 3, half-maximal inhibitory concentration: 3 nM
Compound 3: the middle estimate sits 670-fold (2.82 log units) above what was measured; the measured number lies below the stated range.
By their numbers in this assay, from the lowest: compound 3; then compound 1; then compound 2.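

In this assay, the saturated chain carbon bound to an aromatic carbon proves a highly sensitive place: ethyl(methyl)amino in place of piperidin-1-yl gives a 570-fold lower number from compound 1 to compound 3 (2.75 log units; beyond the scatter) with the rest of compound 1 kept. Among these compounds, the earlier pair differed in more than one place, so this is the first single change that can be read, and it shows that the amine on this chain carbon can by itself shift the antiproliferative read-out by a wide margin. Nothing measured on hand accounts for the size of this step.

Going by these compounds, whether the shift follows from the open chain replacing the six-membered non-aromatic ring, or from ethyl and methyl in particular, stays open, since a single open-chain amine stands against a single ring; dimethylamino, diethylamino and morpholin-4-yl at the same place would separate these readings. Also open, on these data alone, is whether ethyl(methyl)amino in place of piperidin-1-yl would produce a comparable step on the core of compound 2.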